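Methoxy removal in a cinnamate ester series

The source may report more compounds than this note shows. Statements on the series, on what has been measured and on what is new or still open speak of the compounds shown alone.

Compound 1 `CCOC(=O)/C=C/c1cc(OC)c(OC(=O)c2nc(C)c(C)nc2C)c(OC)c1` carries two methoxy groups on the aromatic ring of the shared core; compound 3 `CCOC(=O)/C=C/c1ccc(OC(=O)c2nc(C)c(C)nc2C)c(OC)c1` lacks one of them, the difference being (hydrogen in place of methoxy on an aromatic carbon). In a functional assay on EA.hy 926 cells (Homo sapiens) for cytotoxicity, read by MTT assay, with stated times of 24 h and 12 h, tested at 12.5 uM (a lower number here means a weaker effect, a higher number a stronger effect of the compound at the concentration tested), compound 1 gives 96.6% and compound 3 gives 52.4%; the step of a number 44.2 percentage points lower from compound 1 to compound 3 (beyond the scatter). Compound 2 `CCOC(=O)/C=C/c1cc(OC)ccc1OC(=O)c1nc(C)c(C)nc1C` carries a single methoxy group; how its core differs from that of compound 1 is not broken down here. In this assay compound 2 gives 15.9%, the lowest of the three numbers, beyond the scatter from both compound 3 and compound 1.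

Compound 4 `CCOC(=O)/C=C/c1ccccc1OC(=O)c1nc(C)c(C)nc1C` has not been measured. It differs from compound 2 by hydrogen in place of methoxy on an aromatic carbon. This is the same kind of change as from compound 1 to compound 3, not the same: in compound 1 the methoxy that leaves sits ortho to a large group and meta to a methoxy group, whereas in compound 2 it sits para to a large group. The earlier step removed much of a high starting number; compound 2 already sits low, so a small step is expected, a number 5.9 percentage points lower from compound 2 to compound 4 (within the scatter), because compound 2 gives 15.9% and leaves little room for a drop of the size of a number 44.2 percentage points lower from compound 1 to compound 3 (beyond the scatter). For compound 4 the estimate in this assay is 10%, expected to fall between 2% and 28%.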

Compound 4, a percentage reported as activity, at one concentration (the size of the read-out at that concentration, not a potency): 9.6%
Compound 4: the middle estimate sits 0.4 percentage points above what was measured, and the stated range covers the measured number.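

On the core of compound 2, hydrogen in place of methoxy gives a number 6.3 percentage points lower from compound 2 to compound 4 (within the scatter) in this assay, so compound 2 and compound 4 cannot be told apart in this read-out. This pair and the pair of compound 1 and compound 3 do not show whether the size of the step follows the starting number, the place of the methoxy group that leaves or some other feature of the core, and two pairs cannot separate these readings. What they do show is that the size of the step seen on one core cannot be assumed for the other, as the two steps differ beyond the scatter:
the same change on two cores in this assay, a number 44.2 percentage points lower (beyond the scatter) from compound 1 to compound 3 and a number 6.3 percentage points lower (within the scatter) from compound 2 to compound 4, 37.9 percentage points apart, beyond the scatter of two such steps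

The compounds shown leave open how a hydroxy group, an ethoxy group or an amine would read in place of the methoxy group that is para to a large group, on either core. They also leave open whether a carboxylic acid or a longer chain in place of the ethyl ester of the 2-(ethoxycarbonyl)ethenyl group would change the size of the methoxy step.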